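Fluoro on compound 2: an expected step

The source may hold more compounds than are shown below. What is called first, only, known or untested is meant among the compounds shown, and "the series" means these compounds.

Values in a functional assay on Vero cells (Chlorocebus sabaeus) for cytotoxicity (on this read-out higher numbers stand for weaker inhibition and lower numbers for stronger inhibition), each a limit and not a number:
- Compound 1 `Nc1nc(=O)n([C@@H]2CC(F)(F)[C@H](CO)O2)cc1F` gives > 100000 nM (limit)
- Compound 2 `Nc1ccn([C@@H]2C=C(F)[C@H](CO)O2)c(=O)n1` gives > 100000 nM (limit)
- Compound 3 `Nc1ccn([C@H]2C=C(F)[C@H](CO)O2)c(=O)n1` gives > 100000 nM (limit)

Compound 2 has only the limit > 100000 nM and no number. Compound 4 `Nc1nc(=O)n([C@@H]2C=C(F)[C@H](CO)O2)cc1F` swaps hydrogen for fluoro on an aromatic carbon, ortho to an amino group (fluoro in place of hydrogen on an aromatic carbon). Among the measured compounds shown here, the one measured step (a step that the two limits leave unreadable from compound 2 to compound 3) concerns configuration alone (the fact that compounds 2 and 3 differ only in the configuration as drawn) and says nothing about fluoro. Compound 1 also carries fluoro on an aromatic carbon, and its > 100000 nM is again a limit. With the limit of > 100000 nM in this assay, at which 3 of the 3 values shown sit, as the whole picture, no step beyond the scatter is expected in this assay, in either direction. The expected change is small (a number no higher from compound 2 to compound 4 (the limit leaves the size open)). Compound 4 is estimated at 100000 nM (expected range 40000 nM to 250000 nM).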

Compound 4, half-maximal inhibitory concentration: > 100000 nM
Compound 4 was reported as a limit; the forecaster's own chance of this, stated with the estimate: 85%; the middle value sits exactly at the limit.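

In this assay compound 4 gives > 100000 nM, which is a limit and not a number. Among the compounds shown here, compound 2 also has only a limit, so no step between the two can be read. The compounds shown leave open whether fluoro in place of hydrogen changes the read-out in this assay at all.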